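A few compounds are considered here, and "the series" means these few. Any claim that something is new, unique, unknown or untested is made for them only; others in the source may bear on it.

In a functional assay on Hep 3B2 cells (Homo sapiens) for antiproliferative activity, read by MTT assay, with a stated time of 24 h, tested at 0.05 ug/mL (a higher number here means a stronger effect of the compound at the concentration tested, a lower number a weaker effect), compound 2 `CCc1ccc2nc(C(=O)Nc3c(F)cc(-c4cccc(F)c4)cc3F)c(C)c(O)c2c1` gives 5.62%. Compound 1 `Cc1ccc2nc(C(=O)Nc3c(F)cc(-c4cccc(F)c4)cc3F)c(C)c(O)c2c1` gives 1.52% in this assay, and the step of a number 4.1 percentage points higher from compound 1 to compound 2 (within the scatter) lies within the scatter, so compound 2 stands together with compound 1 rather than apart from it. Compound 3 `Cc1c(C(=O)Nc2c(F)cc(-c3cccc(F)c3)cc2F)nc2ccc(C(F)(F)F)cc2c1O` has not yet been measured; it differs from compound 2 by trifluoromethyl in place of ethyl on an aromatic carbon. Going by the values given here, the only measured step changes a chain carbon, not an aromatic one, and was itself within the scatter, so it bears on this change only loosely. The expected step is a number 0.4 percentage points higher from compound 2 to compound 3 (within the scatter), nothing beyond the scatter. Compound 3 is estimated at 6%, in a range from -6% to 22%.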

Compound 3, a percentage reported as inhibition, at one concentration (the size of the read-out at that concentration, not a potency): 1.35%
The estimate for compound 3 lay 4.7 percentage points above the measured number; the range from low to high includes it.
By their numbers in this assay, from the lowest: compounds 3, 1 and 2 (each within the scatter of the next).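

At this aromatic carbon, trifluoromethyl can now be set against both alkyl groups in this assay, and the result is a number 4.3 percentage points lower from compound 2 to compound 3 (within the scatter) and a number 0.2 percentage points lower from compound 1 to compound 3 (within the scatter), neither leaving the scatter. Methyl, ethyl and trifluoromethyl at this position therefore cannot be told apart at this single concentration. Nothing measured here bears on why these numbers look as they do.

Going by these compounds, whether an amine or a carboxylic acid at this position would give a number beyond the scatter stays open. So does whether these three compounds would separate at a higher concentration.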